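Dropping the Amino Group from the Aryl Substituent

The compounds below may be only part of what the source reports. "The series", "measured", "known", "first", "only" and "open" are said of these compounds alone.

Compound 2 `CCC(C)(C)Cc1c[nH]c(CCc2ccc(-c3cccc(N)n3)cc2)n1` gives the lowest of the two numbers recorded so far. In an in vitro assay on CHO cells for displacement of a labelled ligand from Bombesin receptor subtype-3 (Homo sapiens), read by scintillation counting, with a stated time of 2 h (on this read-out lower numbers stand for stronger inhibition and higher numbers for weaker inhibition), compound 2 gives 7.3 nM, while compound 1 `CCC(C)(C)Cc1c[nH]c(CCc2ccc(-c3cnccn3)cc2)n1` gives 51 nM. Among the measured compounds shown here, the single step measured to date, a 7.0-fold lower number from compound 1 to compound 2 (0.84 log units; beyond the scatter), separates these two compounds. Compound 3 `CCC(C)(C)Cc1c[nH]c(CCc2ccc(-c3cccnc3)cc2)n1` has not yet been measured; it differs from compound 2 in one place: pyridin-3-yl in place of 6-aminopyridin-2-yl on an aromatic carbon. The incoming pyridin-3-yl resembles the pyrazin-2-yl of compound 1 in carrying no hydrogen-bond donor, so the step from compound 1 to compound 2 is the one that bears on this change, and it was a modest one beyond the scatter. Compound 3 is therefore expected to return part of the way toward compound 1, with an estimated step of a 5.5-fold higher number from compound 2 to compound 3 (0.74 log units; beyond the scatter) in this assay. Compound 3 is estimated at 40 nM, within a range of 12 nM to 130 nM.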

Compound 3, half-maximal inhibitory concentration: 7.5 nM
The estimate for compound 3 lay 5.3-fold (0.73 log units) above the measured number, outside the stated range (below it).
By their numbers in this assay, from the lowest: compounds 2 and 3 (each within the scatter of the next); then compound 1.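

In this assay, the change at this aromatic carbon gives a 1.0-fold higher number from compound 2 to compound 3 (0.01 log units; within the scatter), so among these compounds the 6-aminopyridin-2-yl group is not needed for a number of this order, and pyridin-3-yl, with 0 hydrogen-bond donors, serves as well. The other new step, a 6.8-fold lower number from compound 1 to compound 3 (0.83 log units; beyond the scatter), joins two groups that both lack a hydrogen-bond donor, so compound 3 goes against any reading in which the donor alone separates compound 1 from compound 2. Nothing measured here explains why pyrazin-2-yl stands apart from the other two groups.

As far as these compounds go, it remains open whether a plain phenyl ring, with no ring nitrogen, would fit with compound 2 and compound 3 or with compound 1. Also open, from the compounds shown here alone, is what an amino group added to the pyridin-3-yl ring would do.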